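A Methyl on the Benzoyl Ring of Compound 2

The source may hold more compounds than are shown below. What is called first, only, known or untested is meant among the compounds shown, and "the series" means these compounds.

In an assay on cells for displacement of a labelled ligand from adenosine receptor A1 (Homo sapiens), read by scintillation counting, with a stated time of 120 min, tested at 1 uM (a higher number here means more inhibition at the concentration tested (going by the name of the read-out), a lower number less inhibition), compound 1 `Nc1nccn2cc(-c3ccco3)nc12` gives 21%.
Compound 2 `O=C(Nc1nccn2cc(-c3ccccc3)nc12)c1ccccc1` gives 18%.
Compound 3 `O=C(c1ccccc1)N(C(=O)c1ccccc1)c1nccn2cc(-c3ccccc3)nc12` gives 4%.

Compound 2 stands second highest of the three numbers; compound 1 lies within the scatter of it, while compound 3 differs by a number 14 percentage points lower from compound 2 to compound 3 (beyond the scatter), a modest drop for a benzoyl in place of hydrogen on an amide-type nitrogen. Compound 4 `Cc1ccc(C(=O)Nc2nccn3cc(-c4ccccc4)nc23)cc1` differs from compound 2 by methyl in place of hydrogen on an aromatic carbon. Going by the values given here, no measured step touches the benzoyl ring itself, and the one measured step changes a different place, so it offers no guide to this change. Compound 4 is therefore expected to stay within the scatter of compound 2, an estimate of 18% with a range from 5% to 32%. The expected step is no change at the digits printed from compound 2 to compound 4 (within the scatter).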

Compound 4, a percentage reported as inhibition, at one concentration (the size of the read-out at that concentration, not a potency): 26%
Compound 4: middle estimate off by 8 percentage points, on the low side; the measured number falls inside the stated range.
By their numbers in this assay, from the lowest: compound 3; then compounds 2, 1 and 4 (each within the scatter of the next).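

In this assay, going by these compounds alone, phenyl to 4-methylphenyl gives a number 8 percentage points higher from compound 2 to compound 4 (within the scatter) and is the first reading on the benzoyl ring, showing that a methyl para to a large group can be carried there with a step that stays inside the usual scatter. A single methyl is all this shows for this position. No measurement at hand bears on the reason for this result. Still open, going by these compounds, is whether an amine, a carboxylic acid or a longer chain at this same place would give a step beyond the scatter.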